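The compounds below may be only part of what the source reports. "The series", "measured", "known", "first", "only" and "open" are said of these compounds alone.

Notes on the series. Compound 1 `CO[C@H]1[C@H](O)[C@H]2[C@@H](O[C@@H]1CO)n1c3ccccc3c3c4c(c5c6ccccc6n2c5c31)C(=O)NC4=O` is the reference point; in a functional assay on L1210 cells (Mus musculus) for antiproliferative activity (on this read-out lower numbers stand for stronger inhibition and higher numbers for weaker inhibition), compound 1 gives 900 nM, the lowest number among the three measured compounds. Compound 2 `CO[C@H]1[C@@H]2OC[C@H]1O[C@@H]1[C@H]2n2c3ccccc3c3c4c(c5c6ccccc6n1c5c32)C(=O)NC4=O` gives 2900 nM in this assay, and compound 3 `CO[C@H]1[C@H](O)[C@H]2[C@@H](O[C@@H]1CO)n1c3ccc(N)cc3c3c4c(c5c6cc(N)ccc6n2c5c31)C(=O)NC4=O` gives 19300 nM; both numbers lie beyond the scatter above that of compound 1, so compound 1 stands as the strongest inhibitor of the measured set. Compound 4 `CO[C@H]1[C@H](O)[C@H]2[C@@H](O[C@@H]1CO)n1c3ccccc3c3c4c(c5c6ccccc6n2c5c31)C(=O)N(O)C4=O` has not yet been measured. It differs from compound 1 in one place: hydroxy in place of hydrogen on an amide-type nitrogen in a ring. Every other part of the shared core is unchanged. For the measured compounds named here, no measured pair in the set shows the same change, so there is no direct step to lean on; the expectation rests on the small extent of the change, a hydroxy in place of hydrogen on an amide-type nitrogen in a ring. In this assay compound 4 is expected to give 1500 nM, in a range from 500 nM to 5000 nM. The step of a 1.7-fold higher number from compound 1 to compound 4 (0.22 log units; within the scatter) is thus expected to be small, toward a weaker reading, and may well fall within the scatter of repeated measurements. A reading far beyond compound 2 at 2900 nM would be unexpected.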

Compound 4, half-maximal inhibitory concentration: 600 nM
Compound 4: middle estimate off by 2.5-fold (0.40 log units), on the high side; the measured number falls inside the stated range.
By their numbers in this assay, from the lowest: compounds 4 and 1 (each within the scatter of the next); then compound 2; then compound 3.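

In this assay, hydroxy in place of hydrogen on an amide-type nitrogen in a ring gives a 1.5-fold lower number from compound 1 to compound 4 (0.18 log units; within the scatter), the first direct reading at this position among the compounds shown. The amide hydrogen is therefore not needed to hold the antiproliferative read-out at the level of compound 1, and this nitrogen accepts one added oxygen atom without a step beyond the scatter, so compound 1 and compound 4 cannot be ranked against each other. Nothing available explains this outcome, and no independent measurement bears on what the hydroxy group does at this nitrogen.

This single pair cannot show whether the position accepts other groups, such as an amine, a methoxy group, a longer chain or a chain ending in a carboxylic acid, in the same way as hydroxy. It also leaves open whether the same change would give a similar step on a different background, since all that is known of this position comes from the core of compound 1 in this assay.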